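The source may report more compounds than this note shows. Statements on the series, on what has been measured and on what is new or still open speak of the compounds shown alone.

Three compounds have been measured in an in vitro assay on CHOK cells for displacement of a labelled ligand from growth hormone secretagogue receptor type 1 (Homo sapiens); on this read-out lower numbers stand for stronger inhibition and higher numbers for weaker inhibition:

compound 1 `CCc1nc(N)nc(N)c1-c1ccc(NCc2ccc(C(C)=O)cc2)cc1`: 57 nM
compound 2 `Nc1nc(N)c(-c2ccc(NCc3cc(F)c(S(=O)(=O)C(F)(F)F)c(F)c3)cc2)c(COCc2ccccc2)n1`: 1 nM
compound 3 `Nc1nc(N)c(-c2ccc(NCc3ccnc(Cl)c3)cc2)c(COCc2ccccc2)n1`: 1.5 nM

Among these three numbers compound 3 stands second highest. Its nearest neighbour is compound 2, whose number sits within the usual scatter of compound 3, so the two cannot be told apart; compound 1 lies far higher, well beyond the scatter. Compound 4 `Nc1nc(N)c(-c2ccc(NCc3cnc4ccccc4c3)cc2)c(COCc2ccccc2)n1` differs from compound 3 by quinolin-3-yl in place of 2-chloropyridin-4-yl on a saturated chain carbon bound to a nitrogen on an aromatic ring. Among the measured compounds shown here, no pair of measured compounds shows a change of this kind, so there is no direct precedent; the other measured variations at this position, however, stay close together, and the step is expected to be small, not beyond the scatter. Compound 4 is therefore estimated at 2 nM, with a likely range from 0.7 nM to 6 nM. That estimate means an expected step of a 1.3-fold higher number from compound 3 to compound 4 (0.12 log units; within the scatter).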

Compound 4, half-maximal inhibitory concentration: 130 nM
Compound 4: middle estimate off by 65-fold (1.81 log units), on the low side; measured number outside the range, above it.
By their numbers in this assay, from the lowest: compounds 2 and 3 (each within the scatter of the next); then compound 1; then compound 4.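

In this assay, quinolin-3-yl in place of 2-chloropyridin-4-yl gives an 87-fold higher number from compound 3 to compound 4 (1.94 log units; beyond the scatter), so this position does not accept every aromatic ring system alike. Compound 2 and compound 3 alone gave no sign of so sharp a limit. No measurement shown here accounts for the change.

The compounds shown leave open whether the second ring, the missing chlorine or the ring nitrogen's location matters most. A plain pyridin-3-yl or a naphthalen-2-yl group on the same carbon would help separate these possibilities.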